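The compounds below may be only part of what the source reports. "The series", "measured", "known", "first", "only" and "open" are said of these compounds alone.

Measured compounds:
Compound 1 `CC(C)(C)NC(=O)c1[nH]cnc1-c1nc2ccccc2[nH]1` — in a functional assay on MDA-MB-231 cells (Homo sapiens) for inhibition, read by MTT assay, with a stated time of 48 h (a higher number here means a weaker inhibitor, a lower number a stronger inhibitor), compound 1 reaches only a limit of the assay, > 40000 nM.
Compound 2 `O=C(NC1CCC1)c1[nH]cnc1-c1nc2ccccc2[nH]1` — in this assay compound 2 gives 33800 nM.

Compound 1 thus stands at a limit, so only a bound is known for it (the limit of > 40000 nM in this assay, at which 1 of the 2 values shown sits). Compound 3 `O=C(NC1CCCCC1)c1[nH]cnc1-c1nc2ccccc2[nH]1` differs from compound 1 by cyclohexyl in place of tert-butyl on an amide-type nitrogen. Within the data shown here, the one measured step, an at least 1.1-fold lower number from compound 1 to compound 2 (0.07 log units; that floor lies within the scatter), likewise swaps the tert-butyl for a ring on the amide nitrogen, and its floor lies within the scatter. A similar outcome is expected for compound 3, so the step of an at least 1.1-fold lower number from compound 1 to compound 3 (0.05 log units; that floor lies within the scatter) is estimated to be small. Compound 3 is therefore expected to give 35000 nM in this assay, within 15000 nM to 80000 nM, with a fair chance of only a limit again.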

Compound 3, half-maximal inhibitory concentration: 8300 nM
Compound 3: the middle estimate sits 4.2-fold (0.62 log units) above what was measured; measured number below the stated range.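

Among these compounds, the group on the amide nitrogen now makes a clear difference: cyclohexyl in place of cyclobutyl gives a 4.1-fold lower number from compound 2 to compound 3 (0.61 log units; beyond the scatter) in this assay, the first step here between two exact values. Cyclohexyl in place of tert-butyl gives an at least 4.8-fold lower number from compound 1 to compound 3 (0.68 log units; beyond the scatter). That step is only a floor, since compound 1 stands at a limit of the assay: the limit of > 40000 nM in this assay, at which 1 of the 3 values shown sits. On these data alone, whether a larger ring such as cycloheptyl would continue this change remains open. So does whether a ring is needed at all, which a straight hexyl chain could test.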